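Notes on the series: from methoxy to methylamino

The source may hold more compounds than are shown below. What is called first, only, known or untested is meant among the compounds shown, and "the series" means these compounds.

Measured so far in a functional assay on Fem-X cells (Homo sapiens) for cytotoxicity; on this read-out higher numbers stand for weaker inhibition and lower numbers for stronger inhibition
compound 1 `CC1=CCC[C@H]2[C@](C)(CC3=CC(=O)C(SC(C)(C)C)=CC3=O)[C@@H](C)CC[C@]12C` gives 38000 nM
compound 2 `CC1=CCC[C@H]2[C@](C)(CC3=CC(=O)C=CC3=O)[C@@H](C)CC[C@]12C` gives 23900 nM
compound 3 `COC1=CC(=O)C=C(C[C@]2(C)[C@@H](C)CC[C@]3(C)C(C)=CCC[C@@H]23)C1=O` gives 9800 nM

Compound 3 holds the lowest number of the three in this assay and stands beyond the scatter from both others. Compound 4 `CNC1=CC(=O)C=C(C[C@]2(C)[C@@H](C)CC[C@]3(C)C(C)=CCC[C@@H]23)C1=O` carries one change, methylamino in place of methoxy on a double-bonded ring carbon with the rest of the core unchanged.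

For the measured compounds named here, two measured steps bear on it: methoxy in place of hydrogen gave a 2.4-fold lower number from compound 2 to compound 3 (0.39 log units; beyond the scatter) and hydrogen in place of (tert-butyl)sulfanyl gave a 1.6-fold lower number from compound 1 to compound 2 (0.20 log units; within the scatter) as the only other change at such a carbon. Going by the values given here, neither step involves methylamino, and no measurement yet tests that group. With steps of this modest size at that carbon, no step beyond the scatter is expected in this assay and neither direction is favoured.

The estimated step is a 1.1-fold lower number from compound 3 to compound 4 (0.04 log units; within the scatter) and it is expected to stay small. For compound 4 the estimate is 9000 nM within an expected range from 3000 nM to 27000 nM until a measurement is available.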

Compound 4, half-maximal inhibitory concentration: 5200 nM
For compound 4 the middle estimate is 1.7-fold (0.24 log units) above the measured one, and the stated range covers the measured number.
By their numbers in this assay, from the lowest: compounds 4 and 3 (each within the scatter of the next); then compounds 2 and 1 (each within the scatter of the next).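

In this assay, methylamino in place of methoxy on a double-bonded ring carbon gives a 1.9-fold lower number from compound 3 to compound 4 (0.28 log units; within the scatter), so this exchange, which brings in a hydrogen-bond donor, does not separate the two compounds beyond the scatter. Methylamino in place of hydrogen gives a 4.6-fold lower number from compound 2 to compound 4 (0.66 log units; beyond the scatter), which makes it the second group at this carbon, after methoxy, to stand beyond the scatter from hydrogen, whereas compound 1 goes against any general rule for groups here, its (tert-butyl)sulfanyl group staying within the scatter of hydrogen. Nothing at hand explains these steps.

As far as these compounds go, whether an ethylamino chain, a dimethylamino group or an unsubstituted amine at this carbon would stay level with methylamino remains open. So does whether a hydroxyl group there would stand with methoxy and methylamino or with hydrogen.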